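This account rests on a few compounds, and the source may have more. Where it says the series, first, only, none or still open, it means among the compounds named here.

Compound 2 `Cc1cc(C(=O)O)ccc1CN1CCC[C@H](OC(c2cc(Cl)cc(Cl)c2)C(C)O)[C@@H]1c1ccccc1` gives only a limit in an assay on isolated protein for activation of cGMP-dependent protein kinase 1 (Homo sapiens), read by ADP-Glo, with stated times of 30 min and 2 h (a lower number here means that less compound is needed, a higher number that more compound is needed for the effect), > 196000 nM. Compound 1 `Cc1cc(C(=O)O)ccc1CN1CCC[C@H](O[C@H](CO)c2cc(F)cc(F)c2)[C@@H]1c1ccccc1` likewise gives only a limit in this assay, > 200000 nM. Among the compounds with values here, the single measured step, a step that the two limits leave unreadable from compound 1 to compound 2, therefore cannot be read, and the two limits the limit of > 196000 nM in this assay, at which 1 of the 2 values shown sits, and the limit of > 200000 nM in this assay, at which 1 of the 2 values shown sits, are all the evidence there is. Compound 3 `Cc1cc(C(=O)O)ccc1CN1CCC[C@H](O[C@H](CO)c2cccc(Cl)c2)[C@@H]1c1ccccc1` differs from compound 2 by a group of 10 heavy atoms (8 carbon, 1 oxygen, 1 chlorine; one six-membered aromatic ring of carbon only) in place of a group of 12 heavy atoms (9 carbon, 1 oxygen, 2 chlorine; one six-membered aromatic ring of carbon only), on an oxygen on a saturated carbon. With both measured compounds sitting at a limit, no direction can be drawn from them, and compound 3 is expected to remain at or near that limit, with an estimated value of 200000 nM within 50000 nM to 400000 nM. The step from compound 2 to compound 3 is thus expected to be a step that the limit leaves unreadable from compound 2 to compound 3.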

Compound 3, half-maximal effective concentration: 93000 nM
The estimate for compound 3 lay 2.2-fold (0.33 log units) above the measured number; low and high end bracket the measured number.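

Within the data shown here, compound 3 is the only one of the three compounds with a number rather than a limit in this assay, which shows that a change to the group on this oxygen can move the read-out into measurable range. The cleanest comparison, 3-chlorophenyl in place of 3,5-difluorophenyl, gives an at least 2.1-fold lower number from compound 1 to compound 3 (0.33 log units; beyond the scatter); the change that also removes the extra carbon of the chain gives an at least 2.1-fold lower number from compound 2 to compound 3 (0.32 log units; beyond the scatter). From the compounds shown here alone, each of these steps starts from a limit, so its full size stays unknown. Going by these compounds, whether 3-bromophenyl, or an amine in place of the hydroxyl of the 1-(3-chlorophenyl)-2-hydroxyethyl group, would lower the number further remains open.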